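The source may hold more compounds than are shown below. What is called first, only, known or untested is meant among the compounds shown, and "the series" means these compounds.

Of the compounds shown here, two have so far been tested in a functional assay on HCT-116 cells (Homo sapiens) for cytotoxicity, read by MTT assay, with a stated time of 48 h; on this read-out higher numbers stand for weaker inhibition and lower numbers for stronger inhibition. Compound 1 `COc1ccc2[nH]c(-c3ccc(F)cc3)cc(=O)c2c1OC` reached only a limit, > 20000 nM, and gave no exact number. Going by the values given here, compound 2 `COc1cc2c(=O)cc(-c3ccccc3F)[nH]c2cc1O` gave 5800 nM, the only exact number available. The standing of this compound therefore rests on a single measured value and one limit.

Compound 3 `COc1cc2c(=O)cc(-c3ccc(F)cc3)[nH]c2cc1O` has the same atoms as compound 2, joined differently, with 4-fluorophenyl in place of 2-fluorophenyl on an aromatic carbon next to the ring nitrogen (4-fluorophenyl in place of 2-fluorophenyl on an aromatic carbon). Among the compounds with values here, no measured pair of compounds isolates this change, so any expectation for it rests on thin evidence. Compound 1 also carries 4-fluorophenyl, but its core differs from that of compound 2. The result of compound 1, > 20000 nM, is a limit, which offers only a weak hint towards lower potency.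

A small weakening in this assay, not clearly beyond the usual scatter, is therefore expected, with an estimated 1.6-fold higher number from compound 2 to compound 3 (0.19 log units; within the scatter). The estimate for compound 3 is 9000 nM, with an expected range from 3000 nM to 20000 nM.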

Compound 3, half-maximal inhibitory concentration: > 100000 nM
Compound 3 gave a limit, no number; the forecaster's own chance of this, stated with the estimate: 20%; middle value at least 11-fold (1.04 log units) away from the limit.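

In this assay, going by these compounds alone, compounds 2 and 3 form the first pair that isolates the change from 2-fluorophenyl to 4-fluorophenyl on the aromatic carbon next to the ring nitrogen, and the result is an at least 17-fold higher number from compound 2 to compound 3 (1.23 log units; beyond the scatter). The two compounds have the same atoms and differ only in how the fluorophenyl group is joined, so this large step belongs to that single change and shows that activity here depends strongly on which fluorophenyl group is present. Compound 3 reached only a limit, so the step has a lower bound but no exact size: the limit of > 100000 nM in this assay, at which 1 of the 3 values shown sits.

The pair does not show whether unsubstituted phenyl, 3-fluorophenyl or 2-chlorophenyl at this position would keep the activity of compound 2 or lose it as compound 3 does. Compound 1 also carries 4-fluorophenyl but on a different core, its value of > 20000 nM is a limit, and so it leaves open whether the same change would have a similar effect on that core.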